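The source may report more compounds than this note shows. Statements on the series, on what has been measured and on what is new or still open speak of the compounds shown alone.

Measured in a functional assay on the whole organism (strain Kunming) with Mus musculus as the target, in the formalin test, with a stated time of 0.5 h; on this read-out higher numbers stand for an effect only at larger amounts of compound and lower numbers for an effect already at smaller amounts:

- Compound 1 `COc1cc(OC)c(OC)cc1/C=C/COC(=O)/C=C/c1ccc(OC)c(OC)c1` gives 225 umol/kg
- Compound 2 `COc1cc(OC)c(OC)cc1/C=C/COC(=O)/C=C/c1cccc(Br)c1` gives 260 umol/kg
- Compound 3 `COc1cc(OC)c(OC)cc1/C=C/COC(=O)/C=C/c1ccc(OC)c(OC)c1OC` gives 176 umol/kg

Compound 2, at 260 umol/kg, stands level with the other two compounds, since these three values lie within the usual scatter of one another and show no order. The next compound to be tested is compound 4 `COc1cccc(/C=C/C(=O)OC/C=C/c2cc(OC)c(OC)cc2OC)c1`, which carries methoxy in place of bromo on an aromatic carbon and is otherwise the same as compound 2.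

Within the data shown here, no measured step makes this exact swap, but two come close. Putting 3-bromophenyl in place of 3,4-dimethoxyphenyl gave a 1.2-fold higher number from compound 1 to compound 2 (0.06 log units; within the scatter), and adding one methoxy on an aromatic carbon gave a 1.3-fold lower number from compound 1 to compound 3 (0.11 log units; within the scatter). Both steps are small, so changing these groups has so far barely moved the numbers in this assay. The expected change is a 1.2-fold lower number from compound 2 to compound 4 (0.07 log units; within the scatter), with no step beyond the scatter and no direction anticipated. For compound 4 the estimated value is 220 umol/kg, with an expected range from 130 umol/kg to 380 umol/kg.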

Compound 4, dose for half-maximal effect: > 260 umol/kg
Compound 4: only a limit was reported; the forecaster's own chance of this, stated with the estimate: 3%; middle value at least 1.1-fold (0.07 log units) from the limit.
By their numbers in this assay, from the lowest: compounds 3, 1 and 2 (each within the scatter of the next).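

In this assay compound 4 gives > 260 umol/kg, which is a limit of the assay and not a number. Going from 3-bromophenyl to 3-methoxyphenyl thus brought a number no lower from compound 2 to compound 4 (the limit leaves the size open), a point the earlier compounds could not settle, but the size of this step cannot be read. The other new step, hydrogen in place of methoxy on an aromatic carbon, gives an at least 1.1-fold higher number from compound 1 to compound 4 (0.06 log units; that floor lies within the scatter), so even this step's floor does not show that a single methoxy matters here.

As far as these compounds go, the true position of compound 4 remains open, so it cannot yet be said whether this change moves the number beyond the scatter. Also open, from the compounds shown here alone, is whether an amine or a carboxylic acid on this aromatic carbon would shift the dose needed in either direction.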